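Working notes on compound 3, rat microsome stability

This account rests on a few compounds, and the source may have more. Where it says the series, first, only, none or still open, it means among the compounds named here.

Measured so far:
compound 1, `CC(C)C(c1ccc(-c2ccc3cccc(F)c3c2)[nH]c1=O)N1CCN/C1=N\C#N`; in an ADME assay on microsomes from liver (Rattus norvegicus) for metabolic stability (a lower number here means that the compound disappears faster, a higher number that the compound lasts longer), compound 1 gives 0.327 h.
compound 2, `CC(C)C(Cc1nnn[nH]1)c1ccc(-c2ccc3cccc(F)c3c2)[nH]c1=O`; in this assay compound 2 gives 2.08 h.

Going by the values given here, compound 2 holds the higher of the two numbers recorded in this assay, and the one measured step, a 6.4-fold higher number from compound 1 to compound 2 (0.80 log units; beyond the scatter), sets it apart from compound 1 beyond the scatter. Compound 3, `Cc1c[nH]c(C(c2ccc(-c3ccc4cccc(F)c4c3)[nH]c2=O)C(C)C)n1`, is still to be measured in this assay. Its change from compound 2 is 4-methyl-1H-imidazol-2-yl in place of (1H-tetrazol-5-yl)methyl on a saturated chain carbon bound to an aromatic carbon and a saturated chain carbon.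

Among the compounds with values here, only one step is available to judge this. That step, a 6.4-fold higher number from compound 1 to compound 2 (0.80 log units; beyond the scatter), concerns the same place on the saturated chain carbon, but it exchanges a five-membered non-aromatic ring with 2 hetero atoms for the tetrazole; it does not involve the 4-methyl-1H-imidazol-2-yl group entering here. It shows only that what sits at this place can shift the number by a modest amount. With nothing closer to go on, a step in this assay of a 2.1-fold lower number from compound 2 to compound 3 (0.32 log units; beyond the scatter) is expected for compound 3, a modest move downward or none beyond the scatter. Compound 3 is therefore estimated at 1 h, with a range from 0.35 h to 2.8 h.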

Compound 3, half-life: < 0.0667 h
Compound 3: a limit, no number; the forecaster's own chance of this, stated with the estimate: 5%; middle value at least 14-fold (1.17 log units) away from the limit.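

In this assay compound 3 carries a limit of the assay, not a number: the limit of < 0.0667 h in this assay, at which 1 of the 3 values shown sits. Even so, the steps can be read, and 4-methyl-1H-imidazol-2-yl in place of (1H-tetrazol-5-yl)methyl gives an at least 31-fold lower number from compound 2 to compound 3 (1.49 log units; beyond the scatter), while the comparison with the cyclic group of compound 1 gives an at least 4.9-fold lower number from compound 1 to compound 3 (0.69 log units; beyond the scatter). This place on the saturated chain carbon can therefore move the number down as well as up, and compound 3 stands lowest of the three, even though the leaving and entering groups each have 6 heavy atoms, one five-membered aromatic ring and 1 hydrogen-bond donor, so these shared counts alone do not fix the number in compounds 2 and 3.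

The change from compound 2 to compound 3 alters the ring, the methyl on it and the chain carbon of the (1H-tetrazol-5-yl)methyl group all at once, and the compounds shown do not separate these contributions. Also open, on these data alone, is how this place would read with an unsubstituted 1H-imidazol-2-yl, a 1H-tetrazol-5-yl without the methyl link, or a carboxylic acid.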